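A few compounds are considered here, and "the series" means these few. Any claim that something is new, unique, unknown or untested is made for them only; others in the source may bear on it.

Within the data shown here, compound 1 `CCOC(=O)C1=C(C)NC(C)=C(C(=O)OC)C1c1[nH]c(CC)nc1Cl` shows the higher of the two numbers measured so far in an assay on ileum for inhibition of Voltage-dependent L-type calcium channel subunit alpha-1C (Cavia porcellus) (a lower number here means a stronger inhibitor, a higher number a weaker inhibitor), where compound 1 gives 2.02 nM. Among the measured compounds shown here, compound 2 `CCOC(=O)C1=C(C)NC(C)=C(C(=O)OCC)C1c1[nH]c(CC)nc1Cl` gives 0.158 nM in this assay, and the only measured step, a 13-fold lower number from compound 1 to compound 2 (1.11 log units; beyond the scatter), is large. Compound 3 `CCc1nc(Cl)c(C2C(C(=O)OC)=C(C)NC(C)=C2C(=O)OC(C)C)[nH]1` differs from compound 1 by methyl in place of hydrogen on a saturated chain carbon bound to an oxygen next to a carbonyl group and a saturated chain carbon. That measured step adds the same small group to the other ester of the shared core, so a lower number is expected for compound 3, though a smaller step than a 13-fold lower number from compound 1 to compound 2 (1.11 log units; beyond the scatter) seems reasonable with one example. The estimated step is a 3.4-fold lower number from compound 1 to compound 3 (0.53 log units; beyond the scatter), giving compound 3 an expected 0.6 nM, between 0.15 nM and 2.5 nM.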

Compound 3, half-maximal inhibitory concentration: 0.488 nM
The estimate for compound 3 lay 1.2-fold (0.09 log units) above the measured number; measured number inside the range.
By their numbers in this assay, from the lowest: compound 2; then compound 3; then compound 1.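

Going from ethoxy to isopropoxy gives a 4.1-fold lower number from compound 1 to compound 3 (0.62 log units; beyond the scatter) in this assay, so adding a methyl at this saturated chain carbon also lowers the number. The ester change in a 13-fold lower number from compound 1 to compound 2 (1.11 log units; beyond the scatter) lowers it as well, so both single-methyl additions point the same way, one step large and this one modest. Nothing available explains why either number falls.

Still open, going by these compounds, is whether a longer chain such as butyl, or a tert-butyl group, at this ester would lower the number further. It is also unknown how an amine carried on the ester chain would behave.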